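Swapping a Phenyl for tert-Butyl on a Carbonyl Carbon

The source may hold more compounds than are shown below. What is called first, only, known or untested is meant among the compounds shown, and "the series" means these compounds.

For the measured compounds named here, the three compounds measured so far share a core and differ in the groups carried on it. Compound 1 `CC(=O)c1cc(C(=O)c2ccccc2)c(=O)[nH]c1C` is the simplest of them. In an assay for displacement of a labelled ligand from adenosine receptor A1 (Bos taurus), tested at 10 uM (on this read-out higher numbers stand for more inhibition at the one concentration tested (going by the name of the read-out) and lower numbers for less inhibition), compound 1 gives 0%, the lowest of the three numbers. Compound 3 `O=C1CCCc2[nH]c(=O)c(C(=O)c3ccccc3)cc21` comes nearest to it: in this assay compound 3 gives 6%, a number that lies within the scatter of the value of compound 1. Compound 2 `O=C(c1ccccc1)c1cc(C(=O)c2ccccc2)c(=O)[nH]c1-c1ccccc1` stands furthest away: in this assay compound 2 gives 13%, which is beyond the scatter of the value of compound 1, though still a low number on this scale.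

Compound 4 `CC(=O)c1cc(C(=O)C(C)(C)C)c(=O)[nH]c1C` has not yet been measured. It differs from compound 1 in one place: tert-butyl in place of phenyl on a carbonyl carbon. Going by the values given here, no pair of the measured compounds is separated by a single change of this kind, so the size of the step from compound 1 to compound 4 has nothing measured to rest on. With compound 1 at 0% and every measured value low, a step no larger than the scatter, in either direction or none at all, is expected: a number 3 percentage points higher from compound 1 to compound 4 (within the scatter). Compound 4 is therefore estimated at 3%, within a range from 0% to 12%.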

Compound 4, a percentage reported as inhibition, at one concentration (the size of the read-out at that concentration, not a potency): 0%
Compound 4: middle estimate off by 3 percentage points, on the high side; measured number inside the range.
By their numbers in this assay, from the lowest: compounds 1, 4, 3 and 2 (each within the scatter of the next, the first and the last beyond it).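

For the compounds shown here, the exchange of phenyl for tert-butyl on a carbonyl carbon is the first single change that can be read on its own, and in this assay it gives no change at the digits printed from compound 1 to compound 4 (within the scatter) without any rise that stands clear of the usual scatter. It shows that on this carbonyl carbon the aromatic ring can give way to a smaller group with no ring at all, and the number stays as low as before. Since compound 1 starts at 0%, leaving little room for a fall, the step can show only that tert-butyl brought no gain here, not that phenyl and tert-butyl count the same at this position; nothing available bears on why the number stays where it does.

The compounds shown leave open whether a different group on this carbonyl carbon, such as an amine, a carboxylic acid or a longer chain, would move the number beyond the scatter. They also leave open whether tert-butyl in place of phenyl would give the same result on the core of compound 2 or compound 3, which carry other groups.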